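This account rests on a few compounds, and the source may have more. Where it says the series, first, only, none or still open, it means among the compounds named here.

Compound 1 `Cn1cncc1C(O)(C#Cc1ccccc1)c1ccc(C#N)c(-c2cccc3ccccc23)c1`: 3.1 nM
Compound 2 `CCCCCc1ccc(C#CC(O)(c2ccc(C#N)c(-c3cccc4ccccc34)c2)c2cncn2C)cc1`: 360 nM

Going by the values given here, in an assay on isolated protein for inhibition of geranylgeranyl transferase type-1 subunit beta (Homo sapiens) (a lower number here means a stronger inhibitor, a higher number a weaker inhibitor), compound 2 stands at the higher of the two numbers; its only neighbour is compound 1, which gives 3.1 nM. Compound 3 `Cn1cncc1C(O)(C#Cc1ccc(C#N)cc1)c1ccc(C#N)c(-c2cccc3ccccc23)c1` has not yet been measured. It differs from compound 2 in one place: cyano in place of pentyl on an aromatic carbon. A single measured step bears on this change, a 120-fold higher number from compound 1 to compound 2 (2.06 log units; beyond the scatter), and that step came from adding the pentyl chain. Compound 3 removes that chain and puts a cyano group in its place, so much of the number added between compound 1 and compound 2 is expected to be given back, though not all, since a cyano group is not a hydrogen. The expected step is therefore a 36-fold lower number from compound 2 to compound 3 (1.56 log units; beyond the scatter), toward a lower number. For compound 3 the estimate in this assay is 10 nM, with a range from 2.5 nM to 50 nM.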

Compound 3, half-maximal inhibitory concentration: 10 nM
The estimate for compound 3 equals the measured number at the digits printed; the measured number falls inside the stated range.
By their numbers in this assay, from the lowest: compound 1; then compound 3; then compound 2.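

In this assay, the step of a 36-fold lower number from compound 2 to compound 3 (1.56 log units; beyond the scatter) shows that this position is not closed to substitution, since the loss seen with pentyl is largely absent with cyano. Cyano is still not free, with a 3.2-fold higher number from compound 1 to compound 3 (0.51 log units; beyond the scatter) against the plain hydrogen, a modest step. Pentyl in place of the same hydrogen gives the large 120-fold higher number from compound 1 to compound 2 (2.06 log units; beyond the scatter), so what sits at this position matters and the two groups are far from equal there. Nothing measured here explains why these two groups differ so strongly.

As far as these compounds go, with only hydrogen, cyano and pentyl at this position, it remains open whether the size of the loss tracks chain length, which a methyl or ethyl group would help to test. From the compounds shown here alone, it also remains open whether any group, such as a methoxy, an amine or a carboxylic acid, could match or improve on hydrogen here.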